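The source may report more compounds than this note shows. Statements on the series, on what has been measured and on what is new or still open speak of the compounds shown alone.

Compound 1, `Cc1cc(-c2c(F)cc3c(=O)c(Cc4ccc(O)cc4O)cn(C4CC4)c3c2F)cc(C)n1`, in a functional assay on P388 cells (Mus musculus) for cytotoxicity (a lower number here means a stronger inhibitor, a higher number a weaker inhibitor), compound 1 gives 210 nM.
Compound 2, `Cc1cc(-c2c(F)cc3c(=O)c(Cc4c[nH]cn4)cn(C4CC4)c3c2F)cc(C)n1`, in this assay compound 2 gives 390 nM.

The two compounds share one core and differ only in the group on a saturated chain carbon bound to an aromatic carbon. Going by the values given here, compound 2 has only one neighbour in this set, compound 1, and the step of a 1.9-fold higher number from compound 1 to compound 2 (0.27 log units; within the scatter) is too small to separate the two compounds from each other, so compound 2 stands in the same region as compound 1 rather than apart from it.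

Compound 3, `Cc1cc(-c2c(F)cc3c(=O)c(Cc4ccc[nH]4)cn(C4CC4)c3c2F)cc(C)n1`, has not been measured. Its change from compound 2 is 1H-pyrrol-2-yl in place of 1H-imidazol-4-yl on a saturated chain carbon bound to an aromatic carbon. Among the compounds with values here, one measured step bears on this: the exchange of one ring for another at the same place, a 1.9-fold higher number from compound 1 to compound 2 (0.27 log units; within the scatter), which stayed within the scatter. On that basis compound 3 is expected to move by little, a 1.0-fold higher number from compound 2 to compound 3 (0.01 log units; within the scatter), with no direction beyond the scatter. The estimate for compound 3 in this assay is 400 nM, between 150 nM and 1100 nM.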

Compound 3, half-maximal inhibitory concentration: 930 nM
The estimate for compound 3 lay 2.3-fold (0.37 log units) below the measured number, and the stated range covers the measured number.
By their numbers in this assay, from the lowest: compounds 1 and 2 (each within the scatter of the next); then compound 3.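

In this assay, the exchange of one five-membered aromatic ring for another at this place is not neutral: the step is a 2.4-fold higher number from compound 2 to compound 3 (0.38 log units; beyond the scatter), modest but larger than the scatter, which the ring exchange from compound 1 to compound 2 did not show. The two rings have the same count of 5 heavy atoms and each carries 1 hydrogen-bond donor, so the difference in the numbers goes with one ring nitrogen giving way to carbon, and with 1 hydrogen-bond acceptor giving way to 0 hydrogen-bond acceptors, though this single pair cannot say which feature matters. Set against the 2,4-dihydroxyphenyl group, 1H-pyrrol-2-yl gives a 4.4-fold higher number from compound 1 to compound 3 (0.65 log units; beyond the scatter), so compound 3 stands apart from compounds 1 and 2, and the ring on this saturated chain carbon is not freely interchangeable.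

Nothing shown here gives a measured reason for these steps. Still open, on these data alone, is whether a furan-2-yl ring, an open amine or a carboxylic acid at this place, or a longer chain carrying the 1H-imidazol-4-yl ring, would keep the number near that of compound 2 or move it further.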